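The source may report more compounds than this note shows. Statements on the series, on what has been measured and on what is new or still open speak of the compounds shown alone.

For the measured compounds named here, in a functional assay on SW480 cells (Homo sapiens) for cytotoxicity, read by MTT assay, with a stated time of 48 h (on this read-out higher numbers stand for weaker inhibition and lower numbers for stronger inhibition), compound 1 (`COc1cc([C@@H]2C[C@]2(CO)C(=O)Nc2ccccc2Cl)cc(OC)c1OC`) gives 13200 nM, which places it at the low end of the three numbers measured so far. Compound 3 (`CCOC(=O)[C@]1(C(=O)Nc2ccccc2Cl)C[C@H]1c1cc(OC)c(OC)c(OC)c1`) gives 25600 nM, and its ethoxycarbonyl in place of hydroxymethyl on a saturated ring carbon amounts to a 1.9-fold higher number from compound 1 to compound 3 (0.29 log units; within the scatter). Compound 2 (`COc1cc([C@@H]2C[C@]2(CO)C(=O)NCc2ccc(C)cc2)cc(OC)c1OC`) gives 26800 nM, and its 4-methylbenzyl in place of 2-chlorophenyl on an amide-type nitrogen amounts to a 2.0-fold higher number from compound 1 to compound 2 (0.31 log units; beyond the scatter). Compound 4 (`COc1cc([C@H]2C[C@@]2(CO)C(=O)Nc2ccccc2Cl)cc(OC)c1OC`) has not yet been measured, and its relation to compound 1 is this: the two compounds have the same atoms and bonds and differ only in configuration as drawn: 2 of 2 stereo elements differ (all stereocentres are inverted: mirror images); a stereocentre at a saturated ring carbon is drawn S in compound 1 and R in compound 4; a stereocentre at a saturated ring carbon is drawn S in compound 1 and R in compound 4. All stereocentres are inverted, so the two are mirror images. Going by the values given here, neither measured step changes configuration, so both bear on this change only indirectly, and the data hold no measured pair of mirror images. With compound 1 at 13200 nM, a modest move to a higher number is expected, though its size remains uncertain. The estimated change is a 1.4-fold higher number from compound 1 to compound 4 (0.16 log units; within the scatter). Compound 4 is estimated at 19000 nM, with an expected range of 8000 nM to 48000 nM.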

Compound 4, half-maximal inhibitory concentration: > 100000 nM
Compound 4: only a limit was reported; the forecaster's own chance of this, stated with the estimate: 10%; middle value at least 5.2-fold (0.72 log units) away from the limit.
By their numbers in this assay, from the lowest: compounds 1, 3 and 2 (each within the scatter of the next, the first and the last beyond it). At a limit, above all of these: compound 4.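

In this assay compound 4 is reported only as a limit of the assay, > 100000 nM. That limit gives an at least 7.5-fold higher number from compound 1 to compound 4 (0.87 log units; beyond the scatter), the largest step from compound 1 shown, whereas the two earlier steps exchanged groups and left configuration untouched. This step can be ascribed to configuration alone, and to no exchange of groups, because of one fact: the fact that compounds 1 and 4 differ only in the configuration as drawn

Whether inverting compounds 2 and 3 would move their numbers as far stays open, and the true size of this step also stays open because the reading ends at a limit: the limit of > 100000 nM in this assay, at which 1 of the 4 values shown sits. The compounds shown also do not tell how a carboxylic acid or an amine in place of the hydroxymethyl would behave on the core of compound 1 in either configuration.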